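Benzoxazole for chlorobenzothiazole on a triphosphate nucleoside core

A few compounds are considered here, and "the series" means these few. Any claim that something is new, unique, unknown or untested is made for them only; others in the source may bear on it.

Measured compounds:
compound 1 `COc1cccc2sc([C@@H]3O[C@H](COP(=O)(O)OP(=O)(O)OP(=O)(O)O)[C@@H](O)[C@H]3O)nc12` with 700 nM
compound 2 `O=P(O)(O)OP(=O)(O)OP(=O)(O)OC[C@H]1O[C@@H](c2nc3ccc(Cl)cc3s2)[C@H](O)[C@@H]1O` with 8 nM

In a functional assay for agonist activity at P2Y purinoceptor 2 (Homo sapiens), read by FLIPR (on this read-out lower numbers stand for an effect already at smaller amounts and higher numbers for an effect only at larger amounts of compound), compound 2 gives the lower of the two numbers, and compound 1 gives a higher number that lies beyond the scatter. Compound 3 `Cc1ccc2oc([C@@H]3O[C@H](COP(=O)(O)OP(=O)(O)OP(=O)(O)O)[C@@H](O)[C@H]3O)nc2c1` differs from compound 2 by 5-methyl-1,3-benzoxazol-2-yl in place of 6-chloro-1,3-benzothiazol-2-yl on a saturated ring carbon. Among the compounds with values here, no measured pair shows this change, but the gap between 700 nM for compound 1 and 8 nM for compound 2 shows that this position is sensitive. Compound 3 is therefore expected to move toward a higher number, a step of a 10-fold higher number from compound 2 to compound 3 (1.00 log units; beyond the scatter), with an estimate of 80 nM and a range from 15 nM to 500 nM.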

Compound 3, half-maximal effective concentration: 390 nM
Compound 3: middle estimate off by 4.9-fold (0.69 log units), on the low side; low and high end bracket the measured number.
By their numbers in this assay, from the lowest: compound 2; then compounds 3 and 1 (each within the scatter of the next).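

In this assay, putting 5-methyl-1,3-benzoxazol-2-yl in place of 6-chloro-1,3-benzothiazol-2-yl on the saturated ring carbon gives a 49-fold higher number from compound 2 to compound 3 (1.69 log units; beyond the scatter) as a large step from one change in one place. The two groups match in heavy-atom count and in ring types, yet they are clearly not interchangeable at this position. No available measurement accounts for the size of this step. On these data alone, the change alters several atoms at once, so the share of each remains open. A 6-chloro-1,3-benzoxazol-2-yl or 5-methyl-1,3-benzothiazol-2-yl group would separate them.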